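Sulfamoyl in place of methylsulfonyl on a piperazine side chain

The source may hold more compounds than are shown below. What is called first, only, known or untested is meant among the compounds shown, and "the series" means these compounds.

Two close analogues have been characterised in an ADME assay on MT4 cells (Homo sapiens) for cytotoxicity, read by MTT assay, with a stated time of 5 days; on this read-out higher numbers stand for lower toxicity in this test and lower numbers for higher toxicity in this test. Compound 1 `Cc1cc(/C=C/C#N)cc(C)c1Oc1nc(Nc2ccc(CN3CCN(S(N)(=O)=O)CC3)cc2)nc2ccsc12` gives 145000 nM in this assay. Compound 2 `Cc1cc(/C=C/C#N)cc(C)c1Oc1nc(Nc2ccc(CN3CCN(S(C)(=O)=O)CC3)cc2)nc2sccc12` gives 131000 nM in this assay, the lowest of the two numbers, though the gap to compound 1 lies within the usual scatter, so the two values cannot be told apart. Compound 3 `Cc1cc(/C=C/C#N)cc(C)c1Oc1nc(Nc2ccc(CN3CCN(S(N)(=O)=O)CC3)cc2)nc2sccc12` has not yet been measured; it differs from compound 2 in one place (amino in place of methyl on a sulfonyl sulfur). Within the data shown here, no step between measured compounds isolates this change, so nothing in the present data speaks for a shift in either direction. The expectation for compound 3 in this assay is therefore a step from compound 2 of no more than the scatter, a 1.1-fold higher number from compound 2 to compound 3 (0.03 log units; within the scatter). On that basis compound 3 is estimated at 140000 nM, with a range from 70000 nM to 280000 nM in this assay.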

Compound 3, half-maximal cytotoxic concentration: > 217000 nM
Compound 3 was reported as a limit (the forecaster's own chance of this, stated with the estimate: 30%); at least 1.5-fold (0.19 log units) between middle value and limit.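

Among these compounds, this is the first step that isolates amino in place of methyl on a sulfonyl sulfur, and in this assay it reads as an at least 1.6-fold higher number from compound 2 to compound 3 (0.21 log units; that floor lies within the scatter). The result for compound 3 is a limit of the assay and not a number, so this step gives only a floor and not a size: the limit of > 217000 nM in this assay, at which 1 of the 3 values shown sits. The swap of methylsulfonyl to sulfamoyl on this piperazine side chain therefore brought no sign of a lower number, though the floor alone does not establish a real rise.

From the compounds shown here alone, what stays open is how far the true value of compound 3 lies from that of compound 2, and so whether the change has any effect beyond the scatter. Also open, going by these compounds, is how other groups on this sulfonyl sulfur, such as a dimethylamino group or an ethyl chain, would read in this assay.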